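The source may hold more compounds than are shown below. What is called first, only, known or untested is meant among the compounds shown, and "the series" means these compounds.

Series notes, compound 4 pending.

Compound 1 `CO[C@@H]1[C@H](N(C)c2ncc(-c3c[nH]c4ccc(Br)cc34)s2)C[C@H]2O[C@]1(C)n1c3ccccc3c3c4c(c5c6ccccc6n2c5c31)C(=O)NC4` gives 410 nM in a functional assay on MV4-11 cells (Homo sapiens) for antiproliferative activity, read by CellTiter-Glo, with a stated time of 72 h; a higher number here means a weaker inhibitor, a lower number a stronger inhibitor. Compound 2 `COc1ccc2[nH]cc(-c3cnc(N(C)[C@@H]4C[C@H]5O[C@@](C)([C@@H]4OC)n4c6ccccc6c6c7c(c8c9ccccc9n5c8c64)C(=O)NC7)s3)c2c1` differs from it by methoxy in place of bromo on an aromatic carbon and in this assay compound 2 gives 360 nM; the step is a 1.1-fold lower number from compound 1 to compound 2 (0.06 log units; within the scatter). Compound 3 `CO[C@@H]1[C@H](N(C)c2ncc(-c3c[nH]c4ccc(Br)cc34)s2)C[C@H]2O[C@]1(C)n1c3ccccc3c3c4c(c5c6cc(Cl)ccc6n2c5c31)C(=O)NC4` carries a changed core, the difference being (chloro in place of hydrogen on an aromatic carbon), and in this assay compound 3 gives 430 nM; the step is a 1.0-fold higher number from compound 1 to compound 3 (0.02 log units; within the scatter). All three numbers lie within the scatter of one another, so no order among them is claimed.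

Compound 4 `COc1ccc2[nH]cc(-c3cnc(N(C)[C@@H]4C[C@H]5O[C@@](C)([C@@H]4OC)n4c6ccccc6c6c7c(c8c9cc(Cl)ccc9n5c8c64)C(=O)NC7)s3)c2c1` is not yet measured. It differs from compound 3 by methoxy in place of bromo on an aromatic carbon, which is the same change as that from compound 1 to compound 2, made here on the core of compound 3; the place of the change is the same in both pairs. Since the earlier step was a 1.1-fold lower number from compound 1 to compound 2 (0.06 log units; within the scatter), and the core change from compound 1 to compound 3 gave only a 1.0-fold higher number from compound 1 to compound 3 (0.02 log units; within the scatter), the expected step from compound 3 to compound 4 is a 1.1-fold lower number from compound 3 to compound 4 (0.05 log units; within the scatter), about as flat as the earlier one. Compound 4 is therefore expected to give 380 nM in this assay, with a likely range from 200 nM to 750 nM.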

Compound 4, half-maximal inhibitory concentration: 440 nM
Compound 4: the middle estimate sits 1.2-fold (0.06 log units) below what was measured, within the range that was stated.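

On the core of compound 3, methoxy in place of bromo gives a 1.0-fold higher number from compound 3 to compound 4 (0.01 log units; within the scatter) in this assay, and beside the earlier step on the core of compound 1 no difference between the cores can be read: the same change on two cores in this assay, a 1.1-fold lower number (0.06 log units; within the scatter) from compound 1 to compound 2 and a 1.0-fold higher number (0.01 log units; within the scatter) from compound 3 to compound 4, 1.2-fold (0.07 log units) apart, within the scatter of two such steps

Chloro in place of hydrogen on an aromatic carbon of the core, now with methoxy in place of bromo, gives a 1.2-fold higher number from compound 2 to compound 4 (0.09 log units; within the scatter), and this too matches the earlier step: the same change on two cores in this assay, a 1.0-fold higher number (0.02 log units; within the scatter) from compound 1 to compound 3 and a 1.2-fold higher number (0.09 log units; within the scatter) from compound 2 to compound 4, 1.2-fold (0.07 log units) apart, within the scatter of two such steps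

Going by these compounds alone, all four steps lie within the scatter, so the pairs show only that neither change moves the number measurably on either partner; they do not show how a change with a step beyond the scatter would carry from one core to another.

Open, from the compounds shown here alone, is what other groups in place of the bromo or methoxy, such as an amine or a carboxylic acid, would give on these two cores. Also open, going by these compounds, is whether a group other than chloro on the core, such as a nitrile, would alter the step between bromo and methoxy.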